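Pyridinyl carbonyl piperazines on the cystic fibrosis regulator variant

A few compounds are considered here, and "the series" means these few. Any claim that something is new, unique, unknown or untested is made for them only; others in the source may bear on it.

Compound 1, `Cc1cc(C)c2cc(C#N)c(NCCNC(=O)c3ccncc3)nc2c1`: 7300 nM
Compound 2, `Cc1cc(C)c2cc(C#N)c(N3CCN(C(=O)c4ccccn4)CC3)nc2c1`: "not active" (no number reported)

In an in vitro assay on FRT cells with Cystic fibrosis transmembrane conductance regulator variant F508del (Homo sapiens) as the target, read by fluorescence, with a stated time of 24 h, at 37 degrees C, in the presence of a further agent that is not named here (on this read-out lower numbers stand for an effect already at smaller amounts and higher numbers for an effect only at larger amounts of compound), compound 1 gives 7300 nM. Compound 2, the piperazine analogue bearing a pyridin-2-yl carbonyl, is reported in this assay only as "not active" (no number reported), so no single number describes where it stands; all that can be said is that compound 1 has a measured value and compound 2 does not. Going by the values given here, no step between the two is given, and nothing beyond their two values should be read into the pair.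

Compound 3, `Cc1cc(C)c2cc(C#N)c(N3CCN(C(=O)c4ccncc4)CC3)nc2c1`, differs from compound 2 by a single change: pyridin-4-yl in place of pyridin-2-yl on a carbonyl carbon. Because compound 2 is reported only as "not active" (no number reported), the size of the step into compound 3 cannot be stated; the reasonable expectation is that compound 3 remains weak, possibly again without a reportable number in this assay. On that basis compound 3 is estimated at 15000 nM, within a range from 4000 nM to 60000 nM.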

Compound 3, half-maximal effective concentration: "not active" (no number reported)
For compound 3 the study gives words and no number, and the estimate cannot be compared.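

In this assay compound 3 gives "not active" (no number reported) and compound 2 gives "not active" (no number reported), so no step can be read between these two compounds. Nothing shown offers an explanation for this result. The compounds shown leave open whether exchanging pyridin-2-yl for pyridin-4-yl on the carbonyl changes the read-out at all.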